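A few compounds are considered here, and "the series" means these few. Any claim that something is new, unique, unknown or untested is made for them only; others in the source may bear on it.

Measured compounds in a functional assay on BT-549 cells (Homo sapiens) for inhibition, read by sulforhodamine B assay, with a stated time of 48 h; on this read-out higher numbers stand for weaker inhibition of growth and lower numbers for stronger inhibition of growth:
- compound 1, `Nc1cc(N)c2nc(-c3ccccc3)c(Sc3ccc(F)cc3)nc2c1`, gives 43700 nM
- compound 2, `COc1cc(CNc2nc3cc(N)cc(N)c3nc2-c2ccccc2)cc(OC)c1OC`, gives 11200 nM
- compound 3, `CCOC(=O)[C@H](CCC(=O)O)NC(=O)c1ccc(CNc2nc3cc(N)cc(N)c3nc2-c2ccccc2)cc1`, gives only a limit, < 100000 nM

Of the two numbers, compound 1 stands highest; its nearest neighbour is compound 2, with a lower number, and that gap lies beyond the usual scatter. Compound 4, `Nc1cc(N)c2nc(-c3ccccc3)c(NCc3ccc(F)cc3)nc2c1`, differs from compound 1 in one place: (4-fluorobenzyl)amino in place of (4-fluorophenyl)sulfanyl on an aromatic carbon. Within the data shown here, no two measured compounds differ in only one place, so this step is untested. Still, compound 2 also joins its ring to the shared core through an amino linker rather than a sulfanyl one, and its 11200 nM sits below that of compound 1, which suggests a modest gain. The step of a 2.2-fold lower number from compound 1 to compound 4 (0.34 log units; beyond the scatter) is therefore expected to run toward stronger inhibition. Compound 4 is estimated at 20000 nM, between 6000 nM and 60000 nM.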

Compound 4, concentration for total growth inhibition: 3240 nM
Estimate against measurement, compound 4: 6.2-fold (0.79 log units) above; the measured number lies below the stated range.
By their numbers in this assay, from the lowest: compound 4; then compound 2; then compound 1.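

In this assay, this position, on an aromatic carbon next to the ring nitrogen, proves sensitive to its linker: with the fluorinated ring kept, the change gives a 13-fold lower number from compound 1 to compound 4 (1.13 log units; beyond the scatter), a large step toward stronger inhibition of growth. The change alters both the linking atom and the length of the link, and this single step cannot separate the two. Nothing measured here accounts for the gain. Still open, going by these compounds, is whether (4-fluorophenyl)amino or (4-fluorobenzyl)sulfanyl would keep the gain. Also open, on these data alone, is how a longer chain, such as (2-phenylethyl)amino, would fare.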